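Amide substituent changes on a stilbene cinnamamide series

A few compounds are considered here, and "the series" means these few. Any claim that something is new, unique, unknown or untested is made for them only; others in the source may bear on it.

Compound 3 `CCC(C)NC(=O)/C=C/c1c(/C=C/c2ccc(OC)cc2)cc(OC)cc1OC` gives 3430 nM in a functional assay on MCF7 cells (Homo sapiens) for inhibition, read by MTT assay, with a stated time of 48 h; a lower number here means a stronger inhibitor, a higher number a weaker inhibitor.
Compound 1 `CCCCCCCCNC(=O)/C=C/c1c(/C=C/c2ccc(OC)cc2)cc(OC)cc1OC` gives 4280 nM in this assay.
Compound 2 `COc1ccc(/C=C/c2cc(OC)cc(OC)c2/C=C/C(=O)Nc2cc(OC)c(OC)c(OC)c2)cc1` gives 7010 nM in this assay.

Compound 3 carries the lowest of the three numbers, though its nearest neighbour is compound 1, and the step of a 1.2-fold lower number from compound 1 to compound 3 (0.10 log units; within the scatter) stays within the scatter. Among the measured compounds shown here, only the step of a 2.0-fold lower number from compound 2 to compound 3 (0.31 log units; beyond the scatter) reaches beyond it, and that is modest. The shared core of compound 3 is otherwise unchanged across the set; all three compounds differ only in what sits on the amide nitrogen.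

Compound 4 `COc1ccc(/C=C/c2cc(OC)cc(OC)c2/C=C/C(=O)N2CCC(c3ccccc3)CC2)cc1` has not yet been measured in this assay. It differs from compound 3 in one place: 4-phenylpiperidin-1-yl in place of (sec-butyl)amino on a carbonyl carbon. The earlier steps shown here bear on this change only in part, since they swap one substituent on the amide nitrogen for another while keeping the amide hydrogen; compound 4 gives up that hydrogen. The steps of a 1.2-fold lower number from compound 1 to compound 3 (0.10 log units; within the scatter) and a 2.0-fold lower number from compound 2 to compound 3 (0.31 log units; beyond the scatter) show that changes at this position have so far moved the number little. On that basis a small shift is expected, probably towards a higher number, giving an expected step of a 1.3-fold higher number from compound 3 to compound 4 (0.12 log units; within the scatter). Compound 4 is therefore estimated at 4500 nM, within a range from 1500 nM to 14000 nM.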

Compound 4, half-maximal inhibitory concentration: 4230 nM
Compound 4: the middle estimate sits 1.1-fold (0.03 log units) above what was measured; measured number inside the range.
By their numbers in this assay, from the lowest: compounds 3, 4, 1 and 2 (each within the scatter of the next, the first and the last beyond it).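

In this assay, the move to 4-phenylpiperidin-1-yl on the carbonyl carbon gives a 1.2-fold higher number from compound 3 to compound 4 (0.09 log units; within the scatter) and, starting from the octyl amide, a 1.0-fold lower number from compound 1 to compound 4 (0.01 log units; within the scatter). Compound 4 is the only compound shown without the amide hydrogen, and its substituent brings in two rings, with 12 heavy atoms in place of the 5 of (sec-butyl)amino, so the set now shows that this position tolerates the loss of that hydrogen and a much larger ringed group with no change beyond the scatter, which the earlier compounds, all of which keep the hydrogen, could not show. No measurement is available that would explain this result.

The loss of the amide hydrogen and the arrival of the rings come together in compound 4, so their separate contributions remain unresolved; plain piperidin-1-yl, without the phenyl ring, or an N-methyl-N-(sec-butyl)amino group would pull the two apart. Going by these compounds, it also remains open whether a group carrying a basic amine or a carboxylic acid at this position would move the number beyond the scatter, or whether the position stays as flat as it has so far.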